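A few compounds are considered here, and "the series" means these few. Any claim that something is new, unique, unknown or untested is made for them only; others in the source may bear on it.

Compound 1 `C/C=C/C(=O)Nc1ccc(Oc2cccc(OC)c2)cc1` gives 2.1 nM in an assay on isolated protein for binding affinity to melatonin receptor type 1B (Homo sapiens); on this read-out higher numbers stand for weaker inhibition and lower numbers for stronger inhibition.
Compound 2 `CCNC(=O)Nc1ccc(Oc2cccc(OC)c2)cc1` gives 250 nM in this assay.
Compound 3 `CCC(=O)Nc1ccc(Nc2cccc(OC)c2)cc1` gives 1.8 nM in this assay.

Compound 3 carries the lowest number of the three, but its distance to compound 1 lies within the usual scatter, so the two cannot be told apart on these data. Within the data shown here, both stand far from compound 2: the gap between compound 3 and compound 2 is beyond the scatter, as is the only step measured here, a 120-fold higher number from compound 1 to compound 2 (2.08 log units; beyond the scatter), which swaps the whole group on the carbonyl carbon.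

Compound 4 `COc1cccc(Nc2ccc(NC(=O)C(C)C)cc2)c1` differs from compound 3 by one small addition: methyl in place of hydrogen on a saturated chain carbon bound to a carbonyl carbon and a saturated chain carbon. Among the measured compounds shown here, no measured pair shows this kind of change, a methyl added on a saturated chain carbon bound to a carbonyl carbon, so nothing directly bears on it. For the measured compounds named here, the one step available concerns a different change and does not transfer. Without guidance, the expectation for compound 4 in this assay is a small step, a 2.2-fold higher number from compound 3 to compound 4 (0.35 log units; beyond the scatter), likely not beyond the scatter, with some room for a weaker value. Compound 4 is therefore estimated at 4 nM, within a range from 1 nM to 15 nM.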

Compound 4, inhibition constant: 84 nM
Compound 4: the middle estimate sits 21-fold (1.32 log units) below what was measured, outside the stated range (above it).
By their numbers in this assay, from the lowest: compounds 3 and 1 (each within the scatter of the next); then compound 4; then compound 2.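

In this assay, putting methyl in place of hydrogen on the saturated chain carbon bound to a carbonyl carbon and a saturated chain carbon gives a 47-fold higher number from compound 3 to compound 4 (1.67 log units; beyond the scatter). Among these compounds, until now, the only measured step was a swap of the whole group on the carbonyl carbon; this result shows that a far smaller edit, turning propanoylamino into (isopropylcarbonyl)amino, can also shift the number well beyond the scatter. A single added carbon therefore matters at this position, so it cannot be treated as a place where small additions pass unnoticed, although no measurement at hand explains the shift.

The compounds shown leave open whether this rise belongs to any addition on that carbon or to methyl in particular, which a hydroxyl group, a fluorine atom or an amine at the same place could help to separate. They also leave open how a longer straight chain, such as butanoyl, or a ring, such as cyclopropylcarbonyl, would read in this assay when placed on the same amide nitrogen of the core of compound 3.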